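The source may report more compounds than this note shows. Statements on the series, on what has been measured and on what is new or still open speak of the compounds shown alone.

Values in a functional assay on PC-3 cells (Homo sapiens) for inhibition, read by colorimetric assay and sulforhodamine B assay, with a stated time of 48 h (a lower number here means a stronger inhibitor of growth, a higher number a weaker inhibitor of growth), so far
Compound 1 `CCCCCCCCCCCC[C@@H](O)[C@H]1CC[C@H]([C@H](O)CCCCCCCCCCNC(=O)c2cccs2)O1` gives 2290 nM
Compound 2 `CCCCCCCCCCCC[C@@H](O)[C@H]1CC[C@H]([C@H](O)CCCCCCCCCCNC(=O)c2ccco2)O1` gives 100000 nM

Compound 2 holds the higher of the two numbers, which makes it the weaker growth inhibitor of the pair. Compound 3 (`CCCCCCCCCCCC[C@@H](O)[C@H]1CC[C@H]([C@H](O)CCCCCCCCCCNC(=O)c2ccoc2)O1`) differs from compound 2 in one place (furan-3-yl in place of furan-2-yl on a carbonyl carbon) with furan-3-yl in place of furan-2-yl on a carbonyl carbon.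

Within the data shown here, the only measured step that bears on this change is a 44-fold higher number from compound 1 to compound 2 (1.64 log units; beyond the scatter) and it is large. That step alters the ring on the same carbonyl carbon, so a change at this place can move the number far. Among the measured compounds shown here, it swaps thiophen-2-yl for furan-2-yl, however, and no measured step compares the two furan attachments. With compound 2 at 100000 nM as the highest number seen, a move to a lower number in this assay is expected, smaller than the measured step and uncertain in size. The estimate means a 5.0-fold lower number from compound 2 to compound 3 (0.70 log units; beyond the scatter) as the expected change. For compound 3 the estimated value is 20000 nM with an expected range from 3000 nM to 100000 nM on repeat measurement.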

Compound 3, concentration for 50% growth inhibition: 52500 nM
Compound 3: middle estimate off by 2.6-fold (0.42 log units), on the low side, and the stated range covers the measured number.
By their numbers in this assay, from the lowest: compound 1; then compounds 3 and 2 (each within the scatter of the next).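

In this assay, the change from furan-2-yl to furan-3-yl on the carbonyl carbon gives a 1.9-fold lower number from compound 2 to compound 3 (0.28 log units; within the scatter) and so does not separate the two furan attachments. Compound 1 now stands apart from both furans, with a 23-fold higher number from compound 1 to compound 3 (1.36 log units; beyond the scatter) alongside the earlier step, so in these three compounds the large gap goes with the exchange of thiophen-2-yl for a furan, whichever furan attachment is present. No measured evidence on these compounds accounts for this gap or for the lack of a clear difference between the furans.

Open, going by these compounds, is whether thiophen-3-yl would stay close to compound 1 or would instead show that the attachment point matters in the thiophene pair, unlike the furan pair. Also open, on these data alone, is whether a phenyl ring, a pyridine ring or a thiazole ring on the same carbonyl carbon would fall with compound 1 or with compound 2 and compound 3, which would show how far the gap extends beyond these three rings.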